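Aryl change on the shared core, compound 3

This account rests on a few compounds, and the source may have more. Where it says the series, first, only, none or still open, it means among the compounds named here.

Among the compounds with values here, compound 2 `Cn1ccc2c(Oc3ccc(NC(=O)c4cc5cccnc5n(-c5ccc(Cl)cc5)c4=O)cc3F)ccnc21` gives 220 nM in a functional assay on HT-29 cells (Homo sapiens) for antiproliferative activity, read by MTT assay, with a stated time of 72 h (on this read-out lower numbers stand for stronger inhibition and higher numbers for weaker inhibition), the higher of the two numbers measured so far; compound 1 `O=C(Nc1ccc(Oc2ccnc3[nH]ccc23)c(F)c1)c1cc2cccnc2n(-c2ccc(Cl)cc2)c1=O` gives 82 nM, and a 2.7-fold higher number from compound 1 to compound 2 (0.43 log units; beyond the scatter) separates them. Compound 3 `Cn1ccc2c(Oc3ccc(NC(=O)c4cc5cccnc5n(-c5ccc(C(F)(F)F)cc5Cl)c4=O)cc3F)ccnc21` differs from compound 2 by 2-chloro-4-(trifluoromethyl)phenyl in place of 4-chlorophenyl on an aromatic nitrogen. Within the data shown here, the single measured step, a 2.7-fold higher number from compound 1 to compound 2 (0.43 log units; beyond the scatter), concerns methyl in place of hydrogen on an aromatic nitrogen and leaves the aryl group on the aromatic nitrogen of the six-membered aromatic ring untouched; no measured pair varies that group, so nothing indicates a direction for this change. Among the measured compounds shown here, with no bearing step, the expected step of no change at the digits printed from compound 2 to compound 3 (within the scatter) is none beyond the scatter, and the uncertainty around it is wide. Compound 3 is therefore estimated at 220 nM in this assay, with a range of 70 nM to 700 nM.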

Compound 3, half-maximal inhibitory concentration: 5830 nM
Estimate against measurement, compound 3: 27-fold (1.42 log units) below, outside the stated range (above it).
By their numbers in this assay, from the lowest: compound 1; then compound 2; then compound 3.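

The aryl group on the aromatic nitrogen is a place where the number in this assay can move far: 2-chloro-4-(trifluoromethyl)phenyl in place of 4-chlorophenyl gives a 27-fold higher number from compound 2 to compound 3 (1.42 log units; beyond the scatter) in this series. This step is large, whereas the only earlier one, a 2.7-fold higher number from compound 1 to compound 2 (0.43 log units; beyond the scatter) on the methyl change, is modest, so the aryl group is the more sensitive of the two places varied so far. Nothing available explains the size of this step.

The two compounds differ by more than one feature of the aryl group, so the share of the chlorine and that of the trifluoromethyl in the step stay unresolved. Also open, going by these compounds, are how an unsubstituted phenyl, a methoxy or an amine on this aryl ring would read, and whether the step holds with hydrogen on the aromatic nitrogen of compound 1.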